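This account rests on a few compounds, and the source may have more. Where it says the series, first, only, none or still open, it means among the compounds named here.

Three compounds sharing the core of compound 1 `COc1cc(Cc2cnc(/N=C3\C(=O)N(CN4CCN(Cc5ccccc5)CC4)c4ccc(Cl)cc43)nc2N)cc(OC)c1OC` have been run in an ADME assay on MT4 cells (Homo sapiens) for cytotoxicity, read by MTT assay, with a stated time of 5 days; a lower number here means that less compound is tolerated, a higher number that more compound is tolerated. Compound 1 gives 36.1 ug/mL. Compound 2 `COc1cc(Cc2cnc(/N=C3\C(=O)N(CN4CCC(C)CC4)c4ccc(Cl)cc43)nc2N)cc(OC)c1OC` gives 67.4 ug/mL, and compound 3 `COc1cc(Cc2cnc(/N=C3\C(=O)N(CN(Cc4ccccc4)Cc4ccccc4)c4ccc(Cl)cc43)nc2N)cc(OC)c1OC` gives 44.1 ug/mL. Compound 1 carries the lowest of the three numbers, yet both gaps to it fall within the usual scatter, so the three are not separated. Compound 4 `COc1cccc(N2CCN(CN3C(=O)/C(=N\c4ncc(Cc5cc(OC)c(OC)c(OC)c5)c(N)n4)c4cc(Cl)ccc43)CC2)c1` has not yet been tested in this assay. It differs from compound 1 in one place: 3-methoxyphenyl in place of benzyl on an amine nitrogen in a ring. With compound 2 at 67.4 ug/mL and compound 3 at 44.1 ug/mL both within the scatter of compound 1, no step beyond the scatter is expected in either direction. Compound 4 is estimated at 45 ug/mL, range 20 ug/mL to 95 ug/mL, an expected step of a 1.2-fold higher number from compound 1 to compound 4 (0.10 log units; within the scatter).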

Compound 4, half-maximal cytotoxic concentration: 32.6 ug/mL
The estimate for compound 4 lay 1.4-fold (0.14 log units) above the measured number, and the stated range covers the measured number.
By their numbers in this assay, from the lowest: compounds 4, 1, 3 and 2 (each within the scatter of the next, the first and the last beyond it).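

In this assay, 3-methoxyphenyl in place of benzyl on an amine nitrogen in a ring gives a 1.1-fold lower number from compound 1 to compound 4 (0.04 log units; within the scatter). Among these compounds, this is the first step that differs in one place, and it shows that this change, with its added hydrogen-bond acceptor, stays within the scatter. No available measurement bears on the reason for this result.

Still open, as far as these compounds go, is whether a pyridine ring in place of the 3-methoxyphenyl would give a step beyond the scatter. The same holds for a carboxylic acid or an amine on that ring.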